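Swapping one dimethoxyphenyl group for another

The source may report more compounds than this note shows. Statements on the series, on what has been measured and on what is new or still open speak of the compounds shown alone.

Measured so far in a functional assay on K562 cells (Homo sapiens) for antiproliferative activity, read by MTT assay, with a stated time of 48 h; a higher number here means a weaker inhibitor of growth, a lower number a stronger inhibitor of growth:
Compound 1 `COc1ccc(N(C)c2nc(Cl)nc3c2ncn3C)cc1` gives 2300 nM
Compound 2 `COc1ccc(N(C)c2ncnc3c2ncn3Cc2cc(OC)cc(OC)c2)cc1` gives 42000 nM
Compound 3 `COc1ccc(N(C)c2nc(Cl)nc3c2ncn3Cc2ccc(OC)c(OC)c2)cc1` gives 27000 nM

Compound 3 (27000 nM) has the second highest of the three numbers, yet it lies within the usual scatter of compound 2 (42000 nM), so those two cannot be ranked. Among the measured compounds shown here, the gap to compound 1 is clear: the one measured step is large, showing a 12-fold higher number from compound 1 to compound 3 (1.07 log units; beyond the scatter) (a weaker inhibitor of growth).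

Next comes compound 4 `COc1ccc(N(C)c2nc(Cl)nc3c2ncn3Cc2cc(OC)cc(OC)c2)cc1`, which has the same atoms as compound 3, joined differently (3,5-dimethoxyphenyl in place of 3,4-dimethoxyphenyl on a saturated chain carbon bound to an aromatic nitrogen). The 3,4-dimethoxyphenyl gives way to 3,5-dimethoxyphenyl on the same saturated chain carbon bound to an aromatic nitrogen.

The measured step replaced hydrogen with a whole group, so it does not show what this swap does. For the measured compounds named here, no measured pair isolates the swap. Compound 2 also carries 3,5-dimethoxyphenyl on a different core, and compound 2 gives a number (42000 nM) within the scatter of compound 3. No step beyond the scatter is therefore expected in this assay, and the estimated change is small (a 1.1-fold higher number from compound 3 to compound 4 (0.05 log units; within the scatter)). For compound 4 the estimated value is 30000 nM (expected range 11000 nM to 70000 nM).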

Compound 4, concentration for 50% growth inhibition: 42000 nM
For compound 4 the middle estimate is 1.4-fold (0.15 log units) below the measured one; measured number inside the range.
By their numbers in this assay, from the lowest: compound 1; then compounds 3, 2 and 4 (each within the scatter of the next).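

In this assay, the swap of 3,4-dimethoxyphenyl for 3,5-dimethoxyphenyl on the saturated chain carbon bound to an aromatic nitrogen gives a step that cannot be told from repeat-measurement noise (a 1.6-fold higher number from compound 3 to compound 4 (0.19 log units; within the scatter)), so these two arrangements of the same atoms cannot be ranked. The first direct test of the chloro group adds a second such pair: chloro in place of hydrogen on an aromatic carbon leaves the two compounds indistinguishable (no change at the digits printed from compound 2 to compound 4 (within the scatter)), while the large step for 3,5-dimethoxyphenyl in place of hydrogen on that chain carbon (an 18-fold higher number from compound 1 to compound 4 (1.26 log units; beyond the scatter)) shows that a weak result at this position is not confined to the 3,4-dimethoxyphenyl group. No supporting measurement explains any of these steps.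

Still open, going by these compounds, is whether a much smaller addition at this position, such as an ethyl group or an unsubstituted phenyl ring, would keep the number close to that of compound 1. Also open, on these data alone, is whether an amine in place of the chloro would matter on the core of compound 1, where the group on the chain carbon is small.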